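A few compounds are considered here, and "the series" means these few. Any claim that something is new, unique, unknown or untested is made for them only; others in the source may bear on it.

In a physicochemical assay for lipophilicity, read by HPLC, in phosphate buffer, measured as octanol-water partition, at pH 7.4, tested at 100 uM (on this read-out higher numbers stand for higher lipophilicity and lower numbers for lower lipophilicity), compound 3 `CC(C)c1ccccc1-c1cccc(CNc2ccc(OCC(=O)O)c(F)c2)c1` stands higher of the two numbers at 3.45 and compound 1 `CCOc1cc(C)c(-c2cccc(CNc3ccc(OCC(=O)O)c(F)c3)c2)c(C)c1` gives 3.04 as the lower value, a gap beyond the usual scatter. Compound 2 `CCOc1cc(C)c(-c2cccc(COc3ccc(NCC(=O)O)c(F)c3)c2)c(C)c1` has the entry "not determined" (no result reported) and adds no number. Compound 4 `Cc1cc(O)ccc1-c1cccc(CNc2ccc(OCC(=O)O)c(F)c2)c1` is not yet measured and carries 4-hydroxy-2-methylphenyl in place of 2-isopropylphenyl on an aromatic carbon, meta to a large group (4-hydroxy-2-methylphenyl in place of 2-isopropylphenyl on an aromatic carbon). Going by the values given here, no measured pair shows this change. The expectation starts from compound 3 at 3.45 and from the hydrogen-bond donor and acceptor of the entering group, which the leaving group lacks. A fall beyond the scatter is expected in this assay as an estimated step (a number 1.05 log units lower from compound 3 to compound 4 (beyond the scatter)). For compound 4 the estimated value is 2.4 (expected range 1.9 to 2.9).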

Compound 4, distribution coefficient: 1.85
For compound 4 the middle estimate is 0.55 log units above the measured one; the whole stated range lies above it.
By their numbers in this assay, from the lowest: compound 4; then compound 1; then compound 3.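

In this assay, going by these compounds alone, 4-hydroxy-2-methylphenyl in place of 2-isopropylphenyl on an aromatic carbon gives a number 1.60 log units lower from compound 3 to compound 4 (beyond the scatter) and is the first step read at this position. Compound 4 also lies under compound 1 at 3.04 and is the lowest of the three numbers. The step combines two changes, the loss of the isopropyl and the entry of the hydroxy, and the compounds shown do not separate them.

On these data alone, whether an amine or a methoxy group in place of the hydroxy would give a similar step stays open. Nothing available accounts for the size of this step.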